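Amine swap on the shared core: compound 3 to compound 4

The source may hold more compounds than are shown below. What is called first, only, known or untested is meant among the compounds shown, and "the series" means these compounds.

Among the compounds with values here, in a functional assay on A549 cells (Homo sapiens) for inhibition, with a stated time of 72 h (a lower number here means a stronger inhibitor, a higher number a weaker inhibitor), compound 3 `Cc1cc(Cl)ccc1NC(=O)Nc1nc(Sc2c[nH]c3ccccc23)cc(N2CCCC2)n1` gives 8930 nM, the only number recorded in the set. Compound 1 `Cc1cc(Cl)ccc1NC(=O)Nc1nc(Nc2ccccc2)cc(Sc2c[nH]c3ccccc23)n1` gives only a limit, > 50000 nM. Compound 2 `Cc1cc(Cl)ccc1NC(=O)Nc1nc(Sc2c[nH]c3ccccc23)cc(N2CCN(Cc3ccccc3)CC2)n1` likewise gives only a limit, > 50000 nM. Within the data shown here, the sole measured step, an at least 5.5-fold lower number from compound 1 to compound 3 (0.74 log units; beyond the scatter), is bounded by the limit of > 50000 nM in this assay, at which 2 of the 3 values shown sit, and so its true size is open. Compound 4 `Cc1cc(Cl)ccc1NC(=O)Nc1nc(Sc2c[nH]c3ccccc23)cc(N2CCN(c3ccccn3)CC2)n1` differs from compound 3 by 4-(pyridin-2-yl)piperazin-1-yl in place of pyrrolidin-1-yl on an aromatic carbon. Among the measured compounds shown here, no measured step covers this change directly. Compound 2 also carries a piperazine on the core and reaches only a limit. The expected step is a 3.4-fold higher number from compound 3 to compound 4 (0.53 log units; beyond the scatter), with a real chance that only a limit is recorded. Compound 4 is therefore estimated at 30000 nM, between 8000 nM and 100000 nM.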

Compound 4, half-maximal inhibitory concentration: > 50000 nM
Compound 4 ended at the assay's limit (the forecaster's own chance of this, stated with the estimate: 50%); middle value at least 1.6-fold (0.22 log units) from the limit.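

Setting 4-(pyridin-2-yl)piperazin-1-yl in place of pyrrolidin-1-yl on this aromatic carbon gives an at least 5.5-fold higher number from compound 3 to compound 4 (0.74 log units; beyond the scatter), the first direct step from compound 3 to a piperazine. The steps joining compound 4 to compound 2 and compound 1 cannot be read, as both ends are limits. Pyridin-2-yl on the piperazine, like benzyl in compound 2, yields no number, and compound 3 remains the only compound with one: the limit of > 50000 nM in this assay, at which 3 of the 4 values shown sit.

Going by these compounds, whether morpholine, azetidine or an unsubstituted piperazine on this carbon would give a measurable number stays open. So does the true size of the step to compound 4.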